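Removing the Methyl from Compound 3

The compounds below may be only part of what the source reports. "The series", "measured", "known", "first", "only" and "open" are said of these compounds alone.

Of the compounds shown here, three have been tested in a functional assay on A-375 cells (Homo sapiens) for cytotoxicity, read by MTT assay, with a stated time of 72 h, tested at 1 uM; on this read-out higher numbers stand for more inhibition of growth at the one concentration tested and lower numbers for less inhibition of growth. Compound 1 `Cc1cccc(/C(N)=N/NC(=S)N2CCN(c3ccccn3)CC2)n1` gives 58.4%, compound 2 `N/C(=N\NC(=S)N1CCCCCC1)c1ccccn1` gives 67%, and compound 3 `Cc1cccc(/C(N)=N/NC(=S)N2CCSCC2)n1` gives 47.2%, the lowest of the three numbers, with both other values lying beyond the scatter above it. Compound 4 `N/C(=N\NC(=S)N1CCSCC1)c1ccccn1` differs from compound 3 by hydrogen in place of methyl on an aromatic carbon. Among the compounds with values here, no measured pair isolates this change; compound 2 also carries no methyl there, but its other ring differs too, so its value offers only a hint. A modest rise is expected, not clearly beyond the scatter. Compound 4 is estimated at 52% in this assay, with a range from 38% to 66%. This amounts to an expected step of a number 4.8 percentage points higher from compound 3 to compound 4 (within the scatter).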

Compound 4, percent growth inhibition at one concentration: 34%
Beside the measured number, compound 4's estimate is 18 percentage points above it; the whole stated range lies above it.
By their numbers in this assay, from the lowest: compound 4; then compound 3; then compounds 1 and 2 (each within the scatter of the next).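

Within the data shown here, this is the first pair to isolate the position: in this assay, hydrogen in place of methyl on the aromatic carbon next to the ring nitrogen gives a number 13.2 percentage points lower from compound 3 to compound 4 (beyond the scatter). With the rest of the structure unchanged, the methyl is therefore the only difference behind this loss of growth inhibition at the one concentration tested. Nothing in the data explains the step.

On these data alone, whether the same step would appear with the other rings of compound 1 or compound 2 remains open. As far as these compounds go, it is also open how an ethyl, a methoxy or an amine in place of the methyl would compare with compound 3.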